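Swapping a Chlorophenyl for an Aminophenyl on a Shared Core

This account rests on a few compounds, and the source may have more. Where it says the series, first, only, none or still open, it means among the compounds named here.

Measured so far in a functional assay on A549 cells (Homo sapiens) for inhibition, read by MTT assay, with a stated time of 72 h; on this read-out lower numbers stand for stronger inhibition and higher numbers for weaker inhibition:
Compound 1 `CC(C)(C)n1cc2c(n1)C(=O)CC1(CCN(C(=O)c3cc(-c4ccc(Cl)cc4)nc4ccccc34)CC1)O2`: 2330 nM
Compound 2 `CC(C)(C)n1cc2c(n1)C(=O)CC1(CCN(C(=O)c3cc(-c4ccccc4Cl)nc4ccccc34)CC1)O2`: 2180 nM

Compound 2 sits alongside compound 1 on these numbers: a 1.1-fold lower number from compound 1 to compound 2 (0.03 log units; within the scatter). Compound 3 `CC(C)(C)n1cc2c(n1)C(=O)CC1(CCN(C(=O)c3cc(-c4ccc(N)cc4)nc4ccccc34)CC1)O2` carries 4-aminophenyl in place of 2-chlorophenyl on an aromatic carbon. Among the compounds with values here, the one measured step only moved the chlorine around its ring and stayed within the scatter; no measured step exchanges a chlorine for an amino group, so there is no direct guide. The step from compound 2 to compound 3 is therefore expected to be modest, a 1.4-fold higher number from compound 2 to compound 3 (0.14 log units; within the scatter), with wide uncertainty. Compound 3 is estimated at 3000 nM, in a range from 900 nM to 10000 nM.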

Compound 3, half-maximal inhibitory concentration: 970 nM
Estimate against measurement, compound 3: 3.1-fold (0.49 log units) above; low and high end bracket the measured number.
By their numbers in this assay, from the lowest: compound 3; then compounds 2 and 1 (each within the scatter of the next).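

Moving the chlorine around its ring changed little, but this position does respond to the group it carries: in this assay there is a 2.2-fold lower number from compound 2 to compound 3 (0.35 log units; beyond the scatter) with 4-aminophenyl in place of 2-chlorophenyl, and a 2.4-fold lower number from compound 1 to compound 3 (0.38 log units; beyond the scatter) with amino in place of chloro. Both steps are modest, yet both lie beyond the scatter. Nothing available explains this change.

The compounds shown leave open whether a hydroxyl or a methoxy group on this ring would match the amino group. They also leave open how 2-aminophenyl would compare with 4-aminophenyl.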